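The source may report more compounds than this note shows. Statements on the series, on what has been measured and on what is new or still open speak of the compounds shown alone.

Measured in a functional assay on HL-60 cells (Homo sapiens) for cytotoxicity, read by WST assay, with a stated time of 48 h; a lower number here means a stronger inhibitor, a higher number a weaker inhibitor:
- Compound 1 `COC[C@H](C)[C@H](C)C(c1ccc(O)c(OC)c1)c1ccc(O)c(OC)c1`: 82000 nM
- Compound 2 `COc1cc(C(c2ccc(O)c(OC)c2)[C@@H](CO)C(C)C)ccc1O`: > 100000 nM, a limit of the assay and not a number
- Compound 3 `COc1cc(C(c2ccc(O)c(OC)c2)[C@H](CF)C(C)C)ccc1O`: 19000 nM

Compound 3 gives the lowest number of the three, so it is the strongest inhibitor here. The steps leading to it are a 4.3-fold lower number from compound 1 to compound 3 (0.64 log units; beyond the scatter) and an at least 5.2-fold lower number from compound 2 to compound 3 (0.72 log units; beyond the scatter).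

Compound 4 `COc1cc(C(c2ccc(O)c(OC)c2)[C@H](C)[C@@H](C)CO)ccc1O` has not yet been measured. It carries 2-(hydroxymethyl)-1-methylpropyl in place of 1-(fluoromethyl)-2-methylpropyl on a saturated chain carbon bound to two aromatic carbons.

Its closest guides are compound 2, which also has a hydroxymethyl group, and compound 1, whose chain has methoxymethyl instead. Those two sit close together, as an at least 1.2-fold higher number from compound 1 to compound 2 (0.08 log units; that floor lies within the scatter) shows. Read backwards, an at least 5.2-fold lower number from compound 2 to compound 3 (0.72 log units; beyond the scatter) suggests that leaving the fluorinated chain costs activity, so a clear rise in this assay is expected, of similar size to the steps above. The assay may report only a limit.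

The expected step is a 4.7-fold higher number from compound 3 to compound 4 (0.68 log units; beyond the scatter). For compound 4 the estimated value is 90000 nM, with an expected range of 40000 nM to 200000 nM.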

Compound 4, half-maximal inhibitory concentration: > 100000 nM
Compound 4: only a limit was reported; the forecaster's own chance of this, stated with the estimate: 45%; middle value at least 1.1-fold (0.04 log units) away from the limit.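

In this assay the value of compound 4 is a limit and not a number, and it still reads as an at least 5.2-fold higher number from compound 3 to compound 4 (0.72 log units; beyond the scatter), so a second chain carrying hydroxymethyl, 2-(hydroxymethyl)-1-methylpropyl, also falls short of the 1-(fluoromethyl)-2-methylpropyl chain. Against the methoxymethyl chain the result is an at least 1.2-fold higher number from compound 1 to compound 4 (0.08 log units; that floor lies within the scatter), so compound 4 cannot be set apart from compound 1. The step between compound 2 and compound 4 cannot be read, because both values are limits: the limit of > 100000 nM in this assay, at which 2 of the 4 values shown sit.

Still open, as far as these compounds go, is whether the lower number of compound 3 belongs to the fluorine itself or to its whole chain. A chloromethyl or an aminomethyl group on the same saturated chain carbon bound to two aromatic carbons would help separate those two readings.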